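Swapping chlorophenyl for fluorophenyl on the shared core

The compounds below may be only part of what the source reports. "The series", "measured", "known", "first", "only" and "open" are said of these compounds alone.

Measured in a functional assay on HL-60 cells (Homo sapiens) for inhibition, read by MTT assay, with a stated time of 72 h; a lower number here means a stronger inhibitor, a higher number a weaker inhibitor:
Compound 1 `Cc1ccc(C)c(N2CCN(C(=O)c3oc(C)nc3-c3ccccc3)CC2)c1`: 31.3 nM
Compound 2 `Cc1ccc(C)c(N2CCN(C(=O)c3oc(C)nc3-c3ccccc3Cl)CC2)c1`: > 1000 nM, a limit of the assay
Compound 3 `Cc1ccc(C)c(N2CCN(C(=O)c3oc(C)nc3-c3cccc(Cl)c3)CC2)c1`: 345 nM

Compound 3 stands at 345 nM, the higher of the two exact numbers in the series. The gap to the other exact number is an 11-fold higher number from compound 1 to compound 3 (1.04 log units; beyond the scatter). Compound 4 `Cc1ccc(C)c(N2CCN(C(=O)c3oc(C)nc3-c3ccccc3F)CC2)c1` carries 2-fluorophenyl in place of 3-chlorophenyl on an aromatic carbon.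

Within the data shown here, no fluoro compound has been measured, so the evidence is indirect. Both chloro steps raised the number, with an at least 31-fold higher number from compound 1 to compound 2 (1.50 log units; beyond the scatter) as well as the step to compound 3 already given. Exchanging the two chlorophenyl groups gave an at least 2.8-fold lower number from compound 2 to compound 3 (0.46 log units; beyond the scatter). Compound 1 at 31.3 nM, which carries no chloro, suggests that losing the chloro could lower the number, while the large step to compound 2 warns against expecting much.

In this assay, among the measured compounds shown here, no step clearly beyond the scatter is therefore expected, with a slight lean towards a lower number. The expected change is a 1.7-fold lower number from compound 3 to compound 4 (0.24 log units; within the scatter). Compound 4 is estimated at 200 nM, with an expected range of 50 nM to 900 nM.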

Compound 4, half-maximal inhibitory concentration: 319 nM
Estimate against measurement, compound 4: 1.6-fold (0.20 log units) below; measured number inside the range.
By their numbers in this assay, from the lowest: compound 1; then compounds 4 and 3 (each within the scatter of the next). At a limit, above all of these: compound 2.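

In this assay, the fluoro group did not recover the activity of the unsubstituted phenyl, with a 10-fold higher number from compound 1 to compound 4 (1.01 log units; beyond the scatter), so all three halogen-bearing compounds now stand clearly apart from compound 1. Moving from 3-chlorophenyl to 2-fluorophenyl made no measurable difference, with a 1.1-fold lower number from compound 3 to compound 4 (0.03 log units; within the scatter), which shows that a halogen on this phenyl ring can give the same result with a different halogen in a different place. Fluoro in place of chloro on the same ring carbon gave an at least 3.1-fold lower number from compound 2 to compound 4 (0.49 log units; beyond the scatter), a step that rests on a limit for compound 2 and not on a number: the limit of > 1000 nM in this assay, at which 1 of the 4 values shown sits.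

On these data alone, what a methoxy or an amino group on this phenyl ring would do remains open, as does whether 3-fluorophenyl would match 2-fluorophenyl. As far as these compounds go, how far compound 4 truly lies from compound 2 also stays open.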